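Swapping chloro for hydroxy on the pendant phenyl ring

This account rests on a few compounds, and the source may have more. Where it says the series, first, only, none or still open, it means among the compounds named here.

Measured compounds:
- compound 1 `Cn1c(Cn2c(-c3ccccc3)nc3ccccc32)n[nH]c1=S` gives 5% in a functional assay for inhibition, tested at 0.1 mM; a lower number here means less inhibition, a higher number more inhibition at the concentration tested (going by the name of the read-out)
- compound 2 `CNc1nnc(Cn2c(-c3ccc(Cl)cc3)nc3ccccc32)s1` gives 21% in this assay
- compound 3 `COc1ccc(-c2nc3ccccc3n2Cc2n[nH]c(=S)n2C)cc1` gives 5% in this assay

Compound 2 stands highest of the three numbers; both compound 1 and compound 3 lie beyond the scatter below it. Among the measured compounds shown here, the only one-place step measured so far, no change at the digits printed from compound 1 to compound 3 (within the scatter), put methoxy in place of hydrogen on an aromatic carbon of the pendant phenyl ring and moved nothing beyond the scatter.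

The unmeasured compound 4 `CNc1nnc(Cn2c(-c3ccc(O)cc3)nc3ccccc32)s1` differs from compound 2 by hydroxy in place of chloro on an aromatic carbon. That step sits on the same phenyl ring as the earlier methoxy step, but it exchanges one small group for another rather than adding one, and compound 2 carries a different core, so the earlier step bears on it only loosely. For the measured compounds named here, because the one substituent change seen, no change at the digits printed from compound 1 to compound 3 (within the scatter), was flat, the expectation is a small step, a number 6 percentage points lower from compound 2 to compound 4 (within the scatter), downward if anything, within the scatter. The estimate for compound 4 is 15%, ranging from 3% to 30%.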

Compound 4, a percentage reported as inhibition, at one concentration (the size of the read-out at that concentration, not a potency): 5%
Compound 4: middle estimate off by 10 percentage points, on the high side, within the range that was stated.
By their numbers in this assay, from the lowest: compounds 1, 3 and 4 (each within the scatter of the next); then compound 2.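

In this assay, hydroxy in place of chloro gives a number 16 percentage points lower from compound 2 to compound 4 (beyond the scatter). Among the compounds shown here, this is the first one-place change on the pendant phenyl ring to go beyond the scatter, so the group at this position can matter on the core of compound 2. The earlier step, no change at the digits printed from compound 1 to compound 3 (within the scatter), added methoxy to a different core and gave no sign of this, while nothing measured here explains the drop.

On these data alone, it remains open whether an amine, a carboxylic acid or a longer chain such as ethoxy in this position would give a number nearer that of compound 2 or that of compound 4. As far as these compounds go, it is also open whether chloro on the phenyl ring of the core of compound 1 would make any difference there.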